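The source may hold more compounds than are shown below. What is called first, only, known or untested is meant among the compounds shown, and "the series" means these compounds.

Going by the values given here, compound 2 `CCc1sc(CCc2cc(OCC(C)(C)C)cc(NCc3cc(Cl)cc(NC(=O)OC(C)C)c3)n2)nc1C` is one of two compounds measured in an assay on cells for binding affinity to Neuropeptide Y receptor type 1 (Homo sapiens); a lower number here means a stronger inhibitor, a higher number a weaker inhibitor. In this assay compound 2 gives 55 nM, the highest number of the two. The other, compound 1 `CC/C=C\CCOc1cc(CCc2nc(C)c(CC)s2)nc(NCc2cc(Cl)cc(NC(=O)OC(C)C)c2)c1`, in this assay gives 4.7 nM. Among the compounds with values here, the one step between them, a 12-fold higher number from compound 1 to compound 2 (1.07 log units; beyond the scatter), shows that changing the group on the oxygen at this place moves the number well beyond the scatter. Compound 3 `CCc1sc(CCc2cc(OC(CC)CC)cc(NCc3cc(Cl)cc(NC(=O)OC(C)C)c3)n2)nc1C` has not been measured; it keeps every atom of compound 2, but joined differently: pentan-3-yl in place of neopentyl on an oxygen on an aromatic ring. Within the data shown here, only the step from compound 1 to compound 2 bears on this change, and it concerns different groups, so it tells the size of what this place can do rather than the direction. The step of a 1.6-fold lower number from compound 2 to compound 3 (0.20 log units; within the scatter) is therefore expected to be modest, with wide uncertainty. Compound 3 is estimated at 35 nM, between 10 nM and 120 nM.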

Compound 3, half-maximal inhibitory concentration: 5.5 nM
Compound 3: the middle estimate sits 6.4-fold (0.80 log units) above what was measured; the whole stated range lies above it.
By their numbers in this assay, from the lowest: compounds 1 and 3 (each within the scatter of the next); then compound 2.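

In this assay, the step of a 10-fold lower number from compound 2 to compound 3 (1.00 log units; beyond the scatter) shows that this position responds to how the carbons are arranged, not only to how many there are: neopentyl and pentan-3-yl have the same heavy atoms and neither has a ring. The step of a 1.2-fold higher number from compound 1 to compound 3 (0.07 log units; within the scatter) puts pentan-3-yl and the hex-3-en-1-yl chain of compound 1 level, so of these three groups on the oxygen, neopentyl alone stands apart. Nothing available explains why this rearrangement of the same atoms matters so much.

The compounds shown leave open whether the carbon branching directly at the oxygen is what counts, which an isopropyl group or a cyclopentyl ring on the same oxygen would help to test. They also leave open how a 2-methoxyethyl chain or a chain ending in an amine would behave at this place.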